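The source may report more compounds than this note shows. Statements on the series, on what has been measured and on what is new or still open speak of the compounds shown alone.

Compound 1 `O=C(/C=C\c1ccccc1[N+](=O)[O-])N1N=C(c2ccncc2)OC1c1c[nH]c2ccccc12` and compound 2 `O=C(/C=C\c1cccc(F)c1)N1N=C(c2ccncc2)OC1c1c[nH]c2ccccc12` share one core and differ in a single place. In an ADME assay on PANC-1 cells (Homo sapiens) for cytotoxicity, read by MTT assay, with a stated time of 48 h (a lower number here means a stronger inhibitor of growth, a higher number a weaker inhibitor of growth), compound 1 gives > 30 ug/mL, which is a limit of the assay rather than a number. In this assay compound 2 likewise gives > 30 ug/mL, again a limit and not a number. Accordingly a step that the two limits leave unreadable from compound 1 to compound 2, since the limit of > 30 ug/mL in this assay, at which 2 of the 2 values shown sit, is all that either value tells. Compound 2 thus stands at the limit, with no measured number to place it more finely. Compound 3 `O=C(/C=C\c1ccccc1Cl)N1N=C(c2ccncc2)OC1c1c[nH]c2ccccc12` carries 2-chlorophenyl in place of 3-fluorophenyl on a double-bonded chain carbon bound to a double-bonded chain carbon. Within the data shown here, no measured step bears readably on this change, and both measured compounds sit at the limit. Compound 3 is therefore expected to show a step that the limit leaves unreadable from compound 2 to compound 3 in this assay, meaning no departure from the limit beyond the scatter. The estimate for compound 3 in this assay is 40 ug/mL, with a range from 20 ug/mL to 100 ug/mL, and a limit is most likely reported again.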

Compound 3, concentration for 50% growth inhibition: > 30 ug/mL
Compound 3: a limit, no number; the forecaster's own chance of this, stated with the estimate: 80%; the middle value is on the limit's open side.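

In this assay compound 3 gives > 30 ug/mL, again a limit and not a number. No step among compound 1, compound 2 and compound 3 can therefore be read: the limit of > 30 ug/mL in this assay, at which 3 of the 3 values shown sit.

The compounds shown leave open whether 2-nitrophenyl, 3-fluorophenyl and 2-chlorophenyl differ at all in this assay.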